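A few compounds are considered here, and "the series" means these few. Any claim that something is new, unique, unknown or untested is made for them only; others in the source may bear on it.

Measured in a functional assay on the whole organism for agonist activity, with Mus musculus as the target; on this read-out higher numbers stand for an effect only at larger amounts of compound and lower numbers for an effect already at smaller amounts:

compound 1 `CC(=O)N(C)C(C)C#CCn1ccnc1` gives 3 mg/kg.
compound 2 `CC(=O)N(C)C(C)C#CCn1cncc1C` gives > 100 mg/kg, a limit of the assay.
compound 3 `CN(C)C(=O)N(C)CC#CCn1ccnc1` gives > 100 mg/kg, a limit of the assay.

Within the shared core of compound 1 and compound 2, the only change is methyl in place of hydrogen on an aromatic carbon, and it made an at least 33-fold higher number from compound 1 to compound 2 (1.52 log units; beyond the scatter). Compound 3 carries a different core; how the two cores differ is not broken down here. Compound 4 `Cc1cncn1CC#CCN(C)C(=O)N(C)C` is derived from compound 3 by methyl in place of hydrogen on an aromatic carbon, the same change that turned compound 1 into compound 2. Within the data shown here, two of the three values so far sit at the limit of > 100 mg/kg in this assay, at which 2 of the 3 values shown sit.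

For compound 4 the expectation rests on compound 1 and compound 2, where this change produced an at least 33-fold higher number from compound 1 to compound 2 (1.52 log units; beyond the scatter), and on compound 3 already standing at a limit. Compound 4 is therefore expected to remain at or beyond the limit in this assay, an estimated step that the limit leaves unreadable from compound 3 to compound 4. The estimate for compound 4 is 300 mg/kg, between 100 mg/kg and 3000 mg/kg.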

Compound 4, dose for half-maximal effect: > 100 mg/kg
Compound 4: a limit, no number; the forecaster's own chance of this, stated with the estimate: 90%; the middle value does not contradict the limit.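

In this assay, compound 3 and compound 4 both stand at a limit, so no step can be read between them: the limit of > 100 mg/kg in this assay, at which 3 of the 4 values shown sit.

The compounds shown leave open whether methyl in place of hydrogen on this aromatic carbon changes the read-out on the core of compound 3.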